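The source may report more compounds than this note shows. Statements on the series, on what has been measured and on what is new or still open speak of the compounds shown alone.

Measured in an in vitro ADME assay on microsomes from liver (Rattus norvegicus) for metabolic stability; on this read-out lower numbers stand for a shorter-lived compound and higher numbers for a longer-lived compound:
- Compound 1 `Cc1c2c(n3c1CCN(C(=O)[C@H](C)N)CC[C@H](C)Nc1cc-3ccc1C(N)=O)CC(C)(C)CC2=O`: > 0.5 h
- Compound 2 `COCCN1CC[C@H](C)Nc2cc(ccc2C(N)=O)-n2c(c(C)c3c2CC(C)(C)CC3=O)CC1=O`: > 0.5 h
- Compound 3 `Cc1c2c(n3c1CC(=O)NCC[C@H](C)Nc1cc-3ccc1C(N)=O)CC(C)(C)CC2=O`: > 0.5 h

Compound 1 stands at > 0.5 h, which is a limit of this assay and not a number. Compounds 2 and 3 offer no firmer reference, as the series shows (the limit of > 0.5 h in this assay, at which 3 of the 3 values shown sit).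

Compound 4 `Cc1c2c(n3c1CCN(C(=O)[C@@H](C)N)CC[C@H](C)Nc1cc-3ccc1C(N)=O)CC(C)(C)CC2=O` is the mirror-type partner of compound 1 at a single centre: the two compounds have the same atoms and bonds and differ only in configuration as drawn: 1 of 2 stereo elements differ; a stereocentre at a saturated chain carbon is drawn S in compound 1 and R in compound 4. Nothing else in the structure changes.

Among the measured compounds shown here, only one measured step links two compounds that differ in one place, a step that the two limits leave unreadable from compound 2 to compound 3. It concerns a different change, and its size cannot be read. For the measured compounds named here, no measured pair shows what inverting a stereocentre does here, so no step beyond the usual scatter is expected in this assay, and no direction can be favoured. The expected step is a step that the limit leaves unreadable from compound 1 to compound 4. Compound 4 may well return a limit too. For compound 4 the estimated half-life is 0.8 h, with an expected range from 0.4 h to 1.6 h.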

Compound 4, half-life: > 0.5 h
Compound 4: a limit, no number (the forecaster's own chance of this, stated with the estimate: 80%); the middle value is on the limit's open side.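

No step can be read between compound 1 and compound 4, since both values are limits and not numbers: the limit of > 0.5 h in this assay, at which 4 of the 4 values shown sit.

The compounds shown leave open how long each one actually lasts in this assay and whether inverting this stereocentre changes the half-life at all.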